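Aryl ether in place of cyanobenzyl on the shared core

The source may report more compounds than this note shows. Statements on the series, on what has been measured and on what is new or still open speak of the compounds shown alone.

Measured in an ADME assay on HepG2 cells (Homo sapiens) for cytotoxicity, read by luminescence, CellTiter-Glo and ATP content, with a stated time of 72 h; a higher number here means that more compound is needed for the effect, a lower number that less compound is needed:
compound 1 `COc1ccc(F)cc1CNCCCNc1ccnc2cc(Cc3ccc(C#N)cc3)ccc12` gives 6050 nM
compound 2 `COc1cccc(CNCCCNc2ccnc3cc(Oc4ccccc4)ccc23)c1O` gives 6800 nM
compound 3 `CC(C)Cc1ccc2c(NCCCNCc3ccco3)ccnc2c1` gives 16000 nM

Compound 1 sits at the low end of the three numbers; compound 2 lies within the scatter of it, while compound 3 is beyond the scatter, so more of compound 3 is needed for the effect. Compound 4 `COc1ccc(Oc2ccc3c(NCCCNCc4cc(F)ccc4OC)ccnc3c2)cc1` differs from compound 1 by 4-methoxyphenoxy in place of 4-cyanobenzyl on an aromatic carbon. For the measured compounds named here, no pair of measured compounds isolates this change, and compound 3 differs from the others in more than one place, so the measured set gives no step for it. The step from compound 1 to compound 4 in this assay is expected to be small, a 1.2-fold higher number from compound 1 to compound 4 (0.06 log units; within the scatter), with no direction beyond the scatter. Compound 4 is estimated at 7000 nM, with a range from 2500 nM to 20000 nM.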

Compound 4, half-maximal effective concentration: 7000 nM
The estimate for compound 4 equals the measured number at the digits printed, within the range that was stated.
By their numbers in this assay, from the lowest: compounds 1, 2 and 4 (each within the scatter of the next); then compound 3.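

Placing 4-methoxyphenoxy in place of 4-cyanobenzyl on this aromatic carbon gives a 1.2-fold higher number from compound 1 to compound 4 (0.06 log units; within the scatter) in this assay, the only step in one place among the compounds shown. At this position, therefore, the nitrile-bearing benzyl group and the methoxy-bearing aryl ether cannot be told apart in this read-out. No evidence on hand bears on this result.
From the compounds shown here alone, whether an amine or a carboxylic acid at this position would give a step beyond the scatter remains open. Also open, going by these compounds, is whether this swap gives the same result with a different group on the side chain.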